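The source may hold more compounds than are shown below. What is called first, only, known or untested is meant among the compounds shown, and "the series" means these compounds.

Measured so far in a functional assay on CHO-K1 cells for agonist activity at Glucose-dependent insulinotropic receptor (Homo sapiens), read by a luciferase reporter, with a stated time of 5 h; on this read-out higher numbers stand for an effect only at larger amounts of compound and lower numbers for an effect already at smaller amounts:
compound 1, `CC(C)OC(=O)N1CCC(COc2ccc(N3CCN(S(=O)(=O)c4cccnc4)CC3)nc2)CC1`, gives 2000 nM
compound 2, `CCCS(=O)(=O)N1CCN(c2ccc(OCC3CCN(C(=O)NC(C)(C)C)CC3)cn2)CC1`, gives 800 nM
compound 3, `CCCS(=O)(=O)N1CCN(c2ccc(OCC3CCN(C(=O)NC4CCCCC4)CC3)cn2)CC1`, gives > 10000 nM, which is a limit of the assay and not a number.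

Compound 3 therefore stands at the edge of what this assay reports: it sits at the limit of > 10000 nM in this assay, at which 1 of the 3 values shown sits. Among the compounds with values here, the only measured step that touches the same position is an at least 12-fold higher number from compound 2 to compound 3 (1.09 log units; beyond the scatter), where cyclohexyl replaced tert-butyl on the amide-type nitrogen and the number rose sharply.

Compound 4, `CCCS(=O)(=O)N1CCN(c2ccc(OCC3CCN(C(=O)Nc4ccc(C(C)C)cc4)CC3)cn2)CC1`, carries the change (4-isopropylphenyl in place of cyclohexyl on an amide-type nitrogen). Within the data shown here, no measured pair shows an aromatic group at this place, so the measured steps say little about the direction of this change; they only show that the amide-type nitrogen is a sensitive position, and that compound 3 offers no number as a starting point. The expected outcome for compound 4 is therefore wide open, with a real chance that this assay again reports only a limit. As a best estimate, compound 4 is expected to give 6000 nM, within a range of 1000 nM to 30000 nM, which would mean an expected step of an at least 1.6-fold lower number from compound 3 to compound 4 (0.22 log units; that floor lies within the scatter).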

Compound 4, half-maximal effective concentration: 900 nM
The estimate for compound 4 lay 6.7-fold (0.82 log units) above the measured number; the measured number lies below the stated range.
By their numbers in this assay, from the lowest: compounds 2 and 4 (each within the scatter of the next); then compound 1. At a limit, above all of these: compound 3.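

In this assay, 4-isopropylphenyl in place of cyclohexyl on the amide-type nitrogen gives an at least 11-fold lower number from compound 3 to compound 4 (1.04 log units; beyond the scatter). This is the first case shown of an aromatic ring at this place, and the comparison with the small chain-free group of compound 2 gives a 1.1-fold higher number from compound 2 to compound 4 (0.05 log units; within the scatter), so 4-isopropylphenyl and tert-butyl cannot be told apart here, while cyclohexyl stands alone among the three groups as the one that ends at a limit, even though cyclohexyl and 4-isopropylphenyl each bring a six-membered ring. The value of compound 3 is a limit of the assay and not a number, so the step into compound 4 has a floor and no exact size: the limit of > 10000 nM in this assay, at which 1 of the 4 values shown sits.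

The compounds shown leave open which part of 4-isopropylphenyl carries the result, as a plain phenyl ring, a 4-methylphenyl ring or a 4-tert-butylphenyl ring would be needed to separate the ring from the isopropyl group. They also leave open how a charged or hydrogen-bonding group would fare at this place, such as a carboxylic acid or an amine on the aromatic ring.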